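Replacing ethyl with hydroxy, judged from assay limits

The source may report more compounds than this note shows. Statements on the series, on what has been measured and on what is new or still open speak of the compounds shown alone.

Compound 1 (`O=c1[nH]c(=S)ccn1[C@H]1C[C@H](F)[C@@H](CO)O1`) gives > 100 ug/mL as a limit
Compound 2 (`CCc1cn([C@H]2C[C@H](F)[C@@H](CO)O2)c(=O)[nH]c1=O`) gives > 200 ug/mL as a limit
Compound 3 (`O=c1[nH]c(=O)n([C@H]2C[C@H](F)[C@@H](CO)O2)cc1CO`) gives > 200 ug/mL as a limit

All three readings come from an ADME assay on Huh-7 cells (Homo sapiens) for cytotoxicity, read by XTT assay, with a stated time of 2 days (on this read-out lower numbers stand for higher toxicity in this test and higher numbers for lower toxicity in this test), and none of them is an exact number. Compound 2 stands at the limit of > 200 ug/mL in this assay, at which 2 of the 3 values shown sit, and so has no exact place on the scale. Compound 1 stands at the limit of > 100 ug/mL in this assay, at which 1 of the 3 values shown sits, as its own limit.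

The step followed here leads to compound 4 (`O=c1[nH]c(=O)n([C@H]2C[C@H](F)[C@@H](CO)O2)cc1O`), which has not yet been measured. The change is hydroxy in place of ethyl on an aromatic carbon and in words it is hydroxy in place of ethyl on an aromatic carbon.

Within the data shown here, only one measured step bears on it. That step is a step that the two limits leave unreadable from compound 2 to compound 3 and it puts hydroxy in place of methyl on a saturated chain carbon bound to an aromatic carbon. It is a different change at a different atom, so it is only a loose guide, and its size cannot be read. No step beyond the usual scatter is therefore expected in this assay in either direction. The expected step is a number no higher from compound 2 to compound 4 (the limit leaves the size open) and it remains a rough expectation. For compound 4 the estimated value is 200 ug/mL with an expected range from 90 ug/mL to 400 ug/mL and the reading may well turn out to be only a limit again.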

Compound 4, half-maximal cytotoxic concentration: > 100 ug/mL
Compound 4: no number, only a limit; the forecaster's own chance of this, stated with the estimate: 70%; the middle value does not contradict the limit.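

Among these compounds, compound 2, compound 3 and compound 4 all give only limits in this assay, and no step among them can be read. The compounds shown leave open where any of them would give an exact number, and whether ethyl, hydroxymethyl or hydroxy on the aromatic carbon makes any difference to that reading.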